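Benzyl to Phenyl at the Carbonyl of Compound 3

The compounds below may be only part of what the source reports. "The series", "measured", "known", "first", "only" and "open" are said of these compounds alone.

Compound 3 `Cc1coc2c3c(ccc2c1=O)OC[C@H]1[C@@H]3c2c(ccc(C(=O)Cc3ccccc3)c2O)OC1(C)C` is one of three related compounds examined in a functional assay on A549 cells (Homo sapiens) for cytotoxicity, read by MTT assay; a higher number here means a weaker inhibitor, a lower number a stronger inhibitor. In this assay compound 3 gives only a limit, > 100000 nM. Compound 1 `Cc1oc2c3c(ccc2c(=O)c1C)OC[C@H]1[C@@H]3c2c(ccc(C(=O)Cc3ccccc3)c2O)OC1(C)C` likewise gives only a limit in this assay, > 100000 nM. Compound 2 `Cc1oc2c3c(ccc2c(=O)c1C)OC[C@H]1[C@@H]3c2c(ccc(C(=O)c3ccccc3)c2O)OC1(C)C` also returns only a limit in this assay, > 100000 nM. All three values thus sit at the limit of > 100000 nM in this assay, at which 3 of the 3 values shown sit, so the step that the two limits leave unreadable from compound 1 to compound 2 and the step that the two limits leave unreadable from compound 1 to compound 3 cannot be sized from these numbers.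

Compound 4 `Cc1coc2c3c(ccc2c1=O)OC[C@H]1[C@@H]3c2c(ccc(C(=O)c3ccccc3)c2O)OC1(C)C` differs from compound 3 by phenyl in place of benzyl on a carbonyl carbon. The same change carried compound 1 into compound 2, and that step was left unreadable by the two limits. Going by the values given here, no measured step therefore provides a size or a direction for this assay, and nothing beyond the scatter can be forecast from the numbers available. Compound 4 is accordingly expected to give 150000 nM, somewhere between 50000 nM and 500000 nM, most probably reported once more only as a limit. The step that the limit leaves unreadable from compound 3 to compound 4 implied by this estimate is expected to stay unreadable as well.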

Compound 4, half-maximal inhibitory concentration: 17000 nM
Beside the measured number, compound 4's estimate is 8.8-fold (0.95 log units) above it; measured number outside the range, below it.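

Going by these compounds alone, compound 4 is the first compound here to give a number in this assay, and it shows that both places can matter, since phenyl in place of benzyl on a carbonyl carbon (an at least 5.8-fold lower number from compound 3 to compound 4 (0.76 log units; beyond the scatter)) and hydrogen in place of methyl on an aromatic carbon (an at least 5.8-fold lower number from compound 2 to compound 4 (0.76 log units; beyond the scatter)) each lead to it. Neither change alone moved compound 1 off the limit, as compound 2 and compound 3 each carry one of them and stay there, so the effect appears only when the two are combined. The steps from compound 1 remain unreadable because all three earlier compounds stop at the same limit: the limit of > 100000 nM in this assay, at which 3 of the 4 values shown sit.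

Going by these compounds, how far each step truly reaches also stays open, since each starts from a limit. Whether ethyl in place of that hydrogen, or a pyridine ring or a fluorophenyl in place of phenyl, would keep this number is not shown.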